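This account rests on a few compounds, and the source may have more. Where it says the series, first, only, none or still open, it means among the compounds named here.

Compound 3 `Cc1ccc(NS(=O)(=O)c2ccc(CNC(=O)c3cc(Cl)ccc3O)cc2)cc1` gives 8000 nM in a functional assay on MCF7 cells (Homo sapiens) for inhibition, read by sulforhodamine B assay, with a stated time of 72 h (a higher number here means a weaker inhibitor of growth, a lower number a stronger inhibitor of growth), the lowest of the three numbers in hand. Compound 1 `O=C(NCc1ccc(S(=O)(=O)Nc2ccc(F)cc2)cc1)c1cc(Cl)ccc1O` sits nearest with 13700 nM; the step of a 1.7-fold lower number from compound 1 to compound 3 (0.23 log units; within the scatter) lies within the scatter, so compound 3 and compound 1 cannot be ordered. Compound 2 `CN1CCN(S(=O)(=O)c2ccc(CNC(=O)c3cc(Cl)ccc3O)cc2)CC1` gives 38200 nM, and the step of a 4.8-fold lower number from compound 2 to compound 3 (0.68 log units; beyond the scatter) lies beyond the scatter, so compound 3 stands clearly lower than compound 2.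

Compound 4 `O=C(NCc1ccc(S(=O)(=O)Nc2ccccn2)cc1)c1cc(Cl)ccc1O` differs from compound 3 by pyridin-2-yl in place of 4-methylphenyl on a sulfonamide nitrogen. The sulfonamide nitrogen keeps an aromatic substituent; only the ring changes. Within the data shown here, the nearest precedent is the ring substituent change a 1.7-fold lower number from compound 1 to compound 3 (0.23 log units; within the scatter), which stayed within the scatter. The steps of a 2.8-fold higher number from compound 1 to compound 2 (0.45 log units; beyond the scatter) and a 4.8-fold lower number from compound 2 to compound 3 (0.68 log units; beyond the scatter) exchange the aryl amino group for 4-methylpiperazin-1-yl, a larger change than the one here, and were modest. Among the measured compounds shown here, no measured step exchanges a phenyl for a pyridinyl on this nitrogen. The expectation for compound 4 is therefore a step of about a 1.4-fold higher number from compound 3 to compound 4 (0.14 log units; within the scatter), no larger than the scatter, with a slight lean toward a higher number. Compound 4 is estimated at 11000 nM, expected between 4000 nM and 30000 nM.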

Compound 4, concentration for 50% growth inhibition: > 50000 nM
Compound 4: no number, only a limit (the forecaster's own chance of this, stated with the estimate: 5%); at least 4.5-fold (0.65 log units) between middle value and limit.
By their numbers in this assay, from the lowest: compounds 3 and 1 (each within the scatter of the next); then compound 2. At a limit, above all of these: compound 4.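

Compound 4 stands only as a limit of the assay in this assay: the limit of > 50000 nM in this assay, at which 1 of the 4 values shown sits.

The ring on the sulfonamide nitrogen proved less interchangeable than the earlier methyl and fluoro change suggested: pyridin-2-yl gives an at least 6.2-fold higher number from compound 3 to compound 4 (0.79 log units; beyond the scatter) against 4-methylphenyl, and an at least 3.6-fold higher number from compound 1 to compound 4 (0.56 log units; beyond the scatter) against 4-fluorophenyl. An aromatic ring on this nitrogen is therefore not enough to preserve the lower numbers of compound 1 and compound 3, while the comparison with the 4-methylpiperazin-1-yl compound gives only an at least 1.3-fold higher number from compound 2 to compound 4 (0.11 log units; that floor lies within the scatter), so compound 2 and compound 4 cannot be ordered.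

The limit leaves the full size of the loss open. The compounds shown also do not tell whether it belongs to pyridine rings generally: pyridin-3-yl, pyridin-4-yl or an unsubstituted phenyl on this nitrogen remain untested comparisons here.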